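A few compounds are considered here, and "the series" means these few. Any claim that something is new, unique, unknown or untested is made for them only; others in the source may bear on it.

Measured compounds, with the half-maximal inhibitory concentration in a functional assay on MCF7 cells (Homo sapiens) for cytotoxicity, read by MTT assay, with a stated time of 72 h; on this read-out higher numbers stand for weaker inhibition and lower numbers for stronger inhibition:

Compound 1 `COc1ccc(/C=C2\CCC/C(=C\c3cccc(OC)c3OC)C2=O)cc1`: 18600 nM
Compound 2 `COc1cccc(/C=C2\CCC/C(=C\c3ccc(O)cc3)C2=O)c1OC`: > 20000 nM, a limit of the assay rather than a number
Compound 3 `COc1cc(/C=C2\CCC/C(=C\c3ccc(OC)c(OC)c3)C2=O)ccc1O`: 7900 nM

In this assay compound 3 gives the lowest of the two numbers, and the gap to compound 1 lies beyond the scatter. For compound 2 the recorded value is only a limit, (the limit of > 20000 nM in this assay, at which 1 of the 3 values shown sits), so no number is available.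

Compound 1 and compound 2 differ by one change, (hydrogen in place of methyl on an oxygen on an aromatic ring), and that change produced the step of an at least 1.0-fold higher number from compound 1 to compound 2 (0.03 log units; that floor lies within the scatter). Compound 3 and compound 1 differ in more than one place; how the two cores differ is not broken down here.

Compound 4 `COc1ccc(/C=C2\CCC/C(=C\c3ccc(O)c(O)c3)C2=O)cc1OC` is not yet measured. It is reached from compound 3 by hydrogen in place of methyl on an oxygen on an aromatic ring, the same change that leads from compound 1 to compound 2, at the same kind of place: an oxygen on an aromatic ring whose other neighbours are aromatic carbon. Cut one bond further out, the change reads methoxy to hydroxy in both pairs, but the ring carrying it is 4-methoxyphenyl in compound 1 and 4-hydroxy-3-methoxyphenyl in compound 3.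

For compound 4 the expected step in this assay is a 1.8-fold higher number from compound 3 to compound 4 (0.25 log units; within the scatter). That expectation rests on the measured step of an at least 1.0-fold higher number from compound 1 to compound 2 (0.03 log units; that floor lies within the scatter), which gave a higher number, with the size uncertain since compound 2 sits at a limit. Compound 4 is estimated at 14000 nM, with a range from 6000 nM to 35000 nM.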

Compound 4, half-maximal inhibitory concentration: 14400 nM
Compound 4: middle estimate off by 1.0-fold (0.01 log units), on the low side; low and high end bracket the measured number.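

In this assay, the change from methoxy to hydroxy, with hydrogen in place of methyl on an oxygen on an aromatic ring, turning 4-hydroxy-3-methoxyphenyl into 3,4-dihydroxyphenyl, gives a 1.8-fold higher number from compound 3 to compound 4 (0.26 log units; within the scatter), so on this core the step is not separated from repeat measurement. Set beside the same change on the other core, the comparison reads: the same change on two cores in this assay, an at least 1.0-fold higher number (0.03 log units; that floor lies within the scatter) from compound 1 to compound 2 and a 1.8-fold higher number (0.26 log units; within the scatter) from compound 3 to compound 4; the limit leaves it open whether they differ Compound 2 is recorded as > 20000 nM, which is a limit of the assay and not a number, so the two pairs neither show that the change carries from one core to the other with the same size nor show that its size depends on the core, and they give no step beyond the scatter for this change.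

The aromatic rings of the compounds shown carry only methoxy and hydroxy groups, which leaves open how an ethoxy group or a longer chain on that oxygen, or an amine or a carboxylic acid in place of the hydroxy, would read in this assay. Also open, on these data alone, is the true size of the step on the core of compound 1, and whether the change gives a step beyond the scatter on any further core.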